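The compounds below may be only part of what the source reports. "The series", "measured", "known", "first", "only" and "open" are said of these compounds alone.

Measured in an ADME assay on microsomes from liver (Homo sapiens) for metabolic stability, read by LC-MS, using NADPH, with stated times of 10 min and 30 min; a lower number here means slower removal, a higher number faster removal of the compound:
- Compound 1 `CC[C@@H]1c2cc(Cl)ccc2C(=O)N1c1cncc2c1CCC[C@H]2NC(C)=O`: < 3.5 mL/min/kg (a limit)
- Compound 2 `CCC(=O)N[C@@H]1CCCc2c1cncc2N1Cc2cc(Cl)ccc2C1=O`: < 3.5 mL/min/kg (a limit)

Compound 2 stands at < 3.5 mL/min/kg, which is a limit of the assay and not a number. Going by the values given here, the only guide so far is the limit of < 3.5 mL/min/kg in this assay, at which 2 of the 2 values shown sit.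

Compound 3 `CCC(=O)N[C@@H]1CCCc2c1cncc2N1C(=O)c2ccc(Cl)cc2[C@H]1CC` has an ethyl in place of hydrogen on a saturated ring carbon, next to the ring nitrogen: ethyl in place of hydrogen on a saturated ring carbon.

In this assay, the expected result is no change beyond the usual scatter, or at most a small rise in clearance: an at least 1.1-fold higher number from compound 2 to compound 3 (0.05 log units; that floor lies within the scatter). Compound 3 is estimated at 4 mL/min/kg, with an expected range of 2.5 mL/min/kg to 8 mL/min/kg.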

Compound 3, clearance: < 3.5 mL/min/kg
Compound 3 was reported as a limit; the forecaster's own chance of this, stated with the estimate: 55%; middle value at least 1.1-fold (0.05 log units) from the limit.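

Going by these compounds alone, compound 1, compound 2 and compound 3 are all reported only as limits, so no step between them can be read: the limit of < 3.5 mL/min/kg in this assay, at which 3 of the 3 values shown sit. Going by these compounds, whether ethyl in place of hydrogen changes clearance at all stays open.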